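A few compounds are considered here, and "the series" means these few. Any claim that something is new, unique, unknown or untested is made for them only; others in the source may bear on it.

Measured so far in an ADME assay on SW480 cells (Homo sapiens) for cytotoxicity, read by MTT assay, with a stated time of 72 h; a lower number here means a stronger inhibitor, a higher number a weaker inhibitor:

compound 1, `CCCCCN1C(=O)C/C(=C\c2cccc(C(=O)Nc3ccc(C)cc3)c2)C1=O`: > 100000 nM
compound 2, `O=C(Nc1ccccc1)c1cccc(/C=C2\CC(=O)N(c3ccccc3)C2=O)c1`: > 100000 nM
compound 3, `Cc1ccc(N2C(=O)C/C(=C\c3cccc(C(=O)Nc4cccc(F)c4)c3)C2=O)cc1`: 96900 nM

Compound 2, `O=C(Nc1ccccc1)c1cccc(/C=C2\CC(=O)N(c3ccccc3)C2=O)c1`, gives > 100000 nM in this assay; that reading is a limit of the assay and not a number. Compound 1 likewise gives > 100000 nM, which is also a limit. Compound 3 gives 96900 nM, a value close to that same boundary. Taken together, the three compounds share a common core and all sit at or near (the limit of > 100000 nM in this assay, at which 2 of the 3 values shown sit), so none of them shows measurable cytotoxicity in this assay.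

Compound 4, `Cc1ccc(NC(=O)c2cccc(/C=C3\CC(=O)N(c4ccccc4)C3=O)c2)cc1C`, has not yet been measured. It differs from compound 2 in one place: 3,4-dimethylphenyl in place of phenyl on an amide-type nitrogen. With compound 2 at the limit and compound 3 barely inside the measurable range, no step beyond the scatter is expected from this change; the step from compound 2 to compound 4 is estimated as a number no higher from compound 2 to compound 4 (the limit leaves the size open). Compound 4 is therefore expected to read 100000 nM, with a plausible range from 40000 nM to 250000 nM, and most likely as a limit again.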

Compound 4, half-maximal inhibitory concentration: > 100000 nM
Compound 4 gave a limit, no number (the forecaster's own chance of this, stated with the estimate: 70%); the middle value lies on the limit itself.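

Among these compounds, compound 2 and compound 4 both read as limits of the assay, not numbers, so no step between them can be read: the limit of > 100000 nM in this assay, at which 3 of the 4 values shown sit. The compounds shown leave open where the actual values of these two compounds lie, and whether 3,4-dimethylphenyl in place of phenyl changes cytotoxicity at all.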